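Swapping chloro for methyl on the thiophene ring

This account rests on a few compounds, and the source may have more. Where it says the series, first, only, none or still open, it means among the compounds named here.

Compound 1, `CS(=O)(=O)c1ccc(-c2csc(N3N=C(c4ccc(Cl)s4)CC3c3ccc(F)cc3)n2)cc1`, was tested in an ADME assay on NIH3T3 cells (Mus musculus) for cytotoxicity, read by XTT assay, with a stated time of 24 h; a higher number here means a weaker inhibitor, a lower number a stronger inhibitor. In this assay compound 1 gives > 500 ug/mL, which is a limit of the assay and not a number. Compound 2, `N#Cc1ccc(-c2csc(N3N=C(c4ccc(Cl)s4)CC3c3ccc(F)cc3)n2)cc1`, in this assay gives > 500 ug/mL, again a limit rather than a number. The step that the two limits leave unreadable from compound 1 to compound 2 is therefore unreadable. Going by the values given here, compound 3, `COc1ccc(-c2csc(N3N=C(c4ccc(C)s4)CC3c3ccc(F)cc3)n2)cc1`, gives 147 ug/mL in this assay; it holds the only actual number among the three values shown, the other two sitting at the limit of > 500 ug/mL in this assay, at which 2 of the 3 values shown sit. Compound 4, `COc1ccc(-c2csc(N3N=C(c4ccc(Cl)s4)CC3c3ccc(F)cc3)n2)cc1`, differs from compound 3 by chloro in place of methyl on an aromatic carbon. Among the compounds with values here, no measured step concerns this exchange, and the single measured step is unreadable, so the data give no direction for it. Compound 4 carries the same chloro group as compounds 1 and 2. Compound 4 is expected to show a step of a 1.6-fold higher number from compound 3 to compound 4 (0.19 log units; within the scatter) that stays within the scatter. Compound 4 is estimated at 230 ug/mL, between 90 ug/mL and 500 ug/mL, with a fair chance that only a limit is reported.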

Compound 4, half-maximal inhibitory concentration: 103 ug/mL
The estimate for compound 4 lay 2.2-fold (0.35 log units) above the measured number; the range from low to high includes it.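

In this assay, the exchange of 5-methylthiophen-2-yl for 5-chlorothiophen-2-yl gives a 1.4-fold lower number from compound 3 to compound 4 (0.15 log units; within the scatter), so at this position the two groups cannot be told apart. With chloro in place, compound 4 also makes the methoxy group comparable with the other two groups on an aromatic carbon, giving an at least 4.8-fold lower number from compound 2 to compound 4 (0.68 log units; beyond the scatter) and an at least 4.8-fold lower number from compound 1 to compound 4 (0.68 log units; beyond the scatter). Both of these steps start from a limit and not a number, so only their smallest possible size is known: the limit of > 500 ug/mL in this assay, at which 2 of the 4 values shown sit.

As far as these compounds go, only methyl and chloro appear at this thiophene position, so the effect of an amine or a longer chain there remains open. From the compounds shown here alone, whether the nitrile and methylsulfonyl groups would keep their distance from methoxy with methyl on the thiophene also remains open.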